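A few compounds are considered here, and "the series" means these few. Any claim that something is new, unique, unknown or untested is made for them only; others in the source may bear on it.

Of the compounds shown here, three built on one shared core have been measured in an assay on isolated protein for binding affinity to 5-hydroxytryptamine receptor 1B (Homo sapiens); a lower number here means a stronger inhibitor, a higher number a weaker inhibitor. Compound 1 `COc1cc2c(cc1N1C[C@@H](C)N(C)[C@@H](C)C1)N(C(=O)Nc1cccc(Cl)c1Cl)CC2` gives 7.94 nM. Compound 3 `COc1cc2c(cc1N1C[C@@H](C)N(C)[C@@H](C)C1)N(C(=O)Nc1cccc(Cl)c1F)CC2` gives 7.94 nM, and compound 2 `COc1cc2c(cc1N1C[C@@H](C)N(C)[C@@H](C)C1)N(C(=O)c1cccc(Cl)c1)CC2` gives 20 nM. Compound 1 thus stands level with compound 3, the two together holding the lowest numbers of the three, while compound 2 lies farthest from it: a 2.5-fold higher number from compound 1 to compound 2 (0.40 log units; beyond the scatter). Between compound 1 and compound 3 there is no change at the digits printed from compound 1 to compound 3 (within the scatter), and the swing back is a 2.5-fold lower number from compound 2 to compound 3 (0.40 log units; beyond the scatter).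

Compound 4 `COc1cc2c(cc1N1CCN(C)CC1)N(C(=O)Nc1cccc(Cl)c1Cl)CC2` has not yet been measured in this assay. It differs from compound 1 in a single place: 4-methylpiperazin-1-yl in place of 3,4,5-trimethylpiperazin-1-yl on an aromatic carbon. For the measured compounds named here, every measured step in this set alters the group on the carbonyl carbon, and none touches the 3,4,5-trimethylpiperazin-1-yl group, so no measured step bears directly on the change to compound 4. The measured steps only show that the whole set moves within a narrow band. Going by the values given here, with no precedent for this change, a modest move toward a higher number is assumed rather than a large one. Compound 4 is therefore estimated at 16 nM, with a range from 5 nM to 50 nM. For compound 4 the expected step is a 2.0-fold higher number from compound 1 to compound 4 (0.30 log units; within the scatter).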

Compound 4, inhibition constant: 3.98 nM
Compound 4: middle estimate off by 4.0-fold (0.60 log units), on the high side; measured number below the stated range.
By their numbers in this assay, from the lowest: compounds 4, 1 and 3 (each within the scatter of the next); then compound 2.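

For the compounds shown here, measured in this assay, the change on this aromatic carbon, ortho to the methoxy group, gives a 2.0-fold lower number from compound 1 to compound 4 (0.30 log units; within the scatter), the first step in the set that touches this position rather than the group on the carbonyl carbon. With the (2,3-dichlorophenyl)amino group held constant, the 3,4,5-trimethylpiperazin-1-yl group can give way to the smaller 4-methylpiperazin-1-yl group, which has no defined stereocentres, and the number stays within the scatter, so the two added ring methyl groups and the two stereocentres of compound 1 are not required for binding at this level. Nothing available here explains why the two compounds read alike.

As far as these compounds go, this rests on a single pair, so it remains open whether the same swap would behave alike alongside the 3-chlorophenyl group of compound 2 or the (3-chloro-2-fluorophenyl)amino group of compound 3. Also open, from the compounds shown here alone, is how far this position tolerates other changes, such as a piperazin-1-yl group with a hydrogen in place of the methyl on nitrogen, a 4-ethylpiperazin-1-yl group with its longer chain, or a morpholine ring.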